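Cyclopropyl in place of 3-fluorophenyl: expected cytotoxicity

The source may report more compounds than this note shows. Statements on the series, on what has been measured and on what is new or still open speak of the compounds shown alone.

Measured so far in an ADME assay on PANC-1 cells (Homo sapiens) for cytotoxicity, read by sulforhodamine B assay, with a stated time of 48 h, tested at 10 uM; on this read-out lower numbers stand for less inhibition and higher numbers for more inhibition at the one concentration tested (going by the name of the read-out):
- compound 1, `COc1nc2ccc(Br)cc2cc1C(c1ccccc1)n1cc(-c2ccc(Br)cc2)nn1`, gives 10.4%
- compound 2, `CCCCCCc1cn(C(c2ccccc2)c2cc3cc(Br)ccc3nc2OC)nn1`, gives 6.08%
- compound 3, `COc1nc2ccc(Br)cc2cc1C(c1ccccc1)n1cc(-c2cccc(F)c2)nn1`, gives 15.5%

Compound 3 holds the highest of the three numbers, yet its gaps to compound 1 and to compound 2 both lie within the usual scatter, so the three compounds cannot be told apart on these numbers. The next compound, compound 4, `COc1nc2ccc(Br)cc2cc1C(c1ccccc1)n1cc(C2CC2)nn1`, differs from compound 3 in one place: cyclopropyl in place of 3-fluorophenyl on an aromatic carbon.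

Going by the values given here, two measured steps bear on this change. The step from an aromatic arm to a chain, a number 9.4 percentage points higher from compound 2 to compound 3 (within the scatter) read in reverse, and the step between two aromatic arms, a number 5.1 percentage points higher from compound 1 to compound 3 (within the scatter), both stayed within the scatter. The entering cyclopropyl, like the hexyl of compound 2, is a non-aromatic carbon group, so the closest guide is the hexyl compound, whose value in this assay sits a little under that of compound 3. The expectation is therefore a step of no real size: a number 6.5 percentage points lower from compound 3 to compound 4 (within the scatter), a drop that would itself be within the scatter.

Compound 4 is estimated at 9% in this assay, with a likely range from 0% to 20%.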

Compound 4, a percentage reported as inhibition, at one concentration (the size of the read-out at that concentration, not a potency): 21.8%
For compound 4 the middle estimate is 12.8 percentage points below the measured one; measured number above the stated range.
By their numbers in this assay, from the lowest: compounds 2, 1, 3 and 4 (each within the scatter of the next, the first and the last beyond it).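

Cyclopropyl gives the first steps at this position that clear the scatter in this assay: against the hexyl of compound 2 (a number 15.7 percentage points higher from compound 2 to compound 4 (beyond the scatter)) and against the 4-bromophenyl of compound 1 (a number 11.4 percentage points higher from compound 1 to compound 4 (beyond the scatter)), both of modest size. The exchange of 3-fluorophenyl for cyclopropyl stays within the scatter (a number 6.3 percentage points higher from compound 3 to compound 4 (within the scatter)), so compound 3 and compound 4 cannot be told apart, while hexyl and cyclopropyl, both non-aromatic carbon groups, can, which means that a non-aromatic carbon group at this position does not by itself settle the number. Nothing given here explains these differences.

Still open, from the compounds shown here alone, is how the read-out responds to other groups at this position, such as a cyclobutyl ring, a shorter chain like ethyl, an amine or a carboxylic acid, and whether any of them would stand beyond the scatter from compound 4. All these numbers come from a single concentration, so they leave open how the compounds would compare across a range of concentrations.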